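A few compounds are considered here, and "the series" means these few. Any claim that something is new, unique, unknown or untested is made for them only; others in the source may bear on it.

Compound 1, `CCCCCCOc1ccc2c(Cl)ccnc2c1`, was tested in a functional assay on DLD-1 cells (Homo sapiens) for cytotoxicity, read by MTT assay, with a stated time of 48 h (a higher number here means a weaker inhibitor, a lower number a stronger inhibitor), where compound 1 gives 2660 nM. Among the three compounds measured so far, compound 1 holds the second highest number. Its nearest neighbour is compound 2, `CC(C)COc1ccc2c(Cl)ccnc2c1`, which gives 3100 nM in this assay, a difference recorded as a 1.2-fold higher number from compound 1 to compound 2 (0.07 log units; within the scatter). The furthest of the three is compound 3, `CCCCCCOc1ccc2c(NCCN(C)C)ccnc2c1`, which gives 1870 nM in this assay, a difference recorded as a 1.4-fold lower number from compound 1 to compound 3 (0.15 log units; within the scatter). All three numbers therefore sit within the usual scatter of one another, and no order can be read from them.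

The step under study leads from compound 1 to compound 4, `Clc1ccnc2cc(OCCc3ccccc3)ccc12`. The change is phenyl in place of butyl on a saturated chain carbon, two bonds along the chain from an oxygen on an aromatic ring. Going by the values given here, of the two measured steps, only the one from compound 1 to compound 2 touches the same part of the molecule, the chain on the oxygen of the shared core, and that step was a 1.2-fold higher number from compound 1 to compound 2 (0.07 log units; within the scatter), a movement inside the scatter. The step to compound 3 alters a different position and offers no guidance here. On that basis, the step from compound 1 to compound 4 in this assay is expected to be a 1.1-fold lower number from compound 1 to compound 4 (0.03 log units; within the scatter), nothing beyond the scatter in either direction. Compound 4 is therefore estimated at 2500 nM, with a range from 1100 nM to 6000 nM.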

Compound 4, half-maximal inhibitory concentration: 3380 nM
Beside the measured number, compound 4's estimate is 1.4-fold (0.13 log units) below it; the range from low to high includes it.
By their numbers in this assay, from the lowest: compounds 3, 1, 2 and 4 (each within the scatter of the next).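

In this assay, phenyl in place of butyl on a saturated chain carbon, two bonds along the chain from an oxygen on an aromatic ring, gives a step that stays inside the scatter (a 1.3-fold higher number from compound 1 to compound 4 (0.10 log units; within the scatter)). Going by these compounds alone, the only earlier step on this chain (a 1.2-fold higher number from compound 1 to compound 2 (0.07 log units; within the scatter)) exchanged one saturated group for another, whereas this one is the first to place an aromatic ring at the end of the chain, and the number still does not move beyond the scatter. No measured evidence is at hand that bears on this result.

The compounds shown leave open whether any group at this position can move the number beyond the scatter, for example an amine or a carboxylic acid at the end of the chain, a phenyl ring carrying a methoxy group or a fluorine, or a much longer chain. Within the data shown here, they also leave open whether the (2-(dimethylamino)ethyl)amino group, so far seen only with the hexyloxy chain of the shared core, would give a similar number alongside the phenyl-bearing chain.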